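A few compounds are considered here, and "the series" means these few. Any claim that something is new, unique, unknown or untested is made for them only; others in the source may bear on it.

Measured so far in a functional assay on T47D cells (Homo sapiens) for cytotoxicity, read by CCK-8 assay, with a stated time of 4 days; a lower number here means a stronger inhibitor, a higher number a weaker inhibitor:
- compound 1 `Oc1ccc(-c2cc(-c3ccc(O)cc3)nc(-c3ccc(O)cc3)c2)cc1`, compound 1 gives 4270 nM
- compound 2 `Oc1ccc(-c2cc(-c3ccc(O)cc3)nc(-c3cccc(O)c3)c2)cc1`, compound 2 gives 4470 nM
- compound 3 `Oc1ccc(-c2cc(-c3cccc(O)c3)nc(-c3ccccc3O)c2)cc1`, compound 3 gives 4810 nM

Compound 3 returns the highest of the three numbers, but this means little: the step of a 1.1-fold higher number from compound 2 to compound 3 (0.03 log units; within the scatter) is within the scatter, and the values of compound 1 and compound 3 sit equally close to one another. Across the three, moving a hydroxyl around the pendant phenyl groups has so far left the readout flat.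

Compound 4 `Oc1ccc(-c2cc(-c3ccc(O)cc3)nc(-c3ccccc3O)c2)cc1` is the next member. Relative to compound 3 the change is 4-hydroxyphenyl in place of 3-hydroxyphenyl on an aromatic carbon. Among the measured compounds shown here, the one measured step that bears on it directly is a 1.0-fold higher number from compound 1 to compound 2 (0.02 log units; within the scatter), the same swap run the other way at the same position, and it was within the scatter; a 1.1-fold higher number from compound 2 to compound 3 (0.03 log units; within the scatter) points the same way. Nothing in the series suggests this move should matter, so compound 4 is expected to show a 1.1-fold lower number from compound 3 to compound 4 (0.03 log units; within the scatter), no shift beyond the scatter. The estimate for compound 4 is 4500 nM, with a range of 2500 nM to 8000 nM.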

Compound 4, half-maximal inhibitory concentration: 50000 nM
Compound 4: middle estimate off by 11-fold (1.05 log units), on the low side, outside the stated range (above it).
By their numbers in this assay, from the lowest: compounds 1, 2 and 3 (each within the scatter of the next); then compound 4.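

In this assay, the group next to the ring nitrogen proves sensitive to its partner: with 2-hydroxyphenyl present, 4-hydroxyphenyl in place of 3-hydroxyphenyl gives a 10-fold higher number from compound 3 to compound 4 (1.02 log units; beyond the scatter), whereas the same exchange on the other core shows no shift beyond the scatter: the same change on two cores in this assay, a 1.0-fold higher number (0.02 log units; within the scatter) from compound 1 to compound 2 and a 10-fold lower number (1.02 log units; beyond the scatter) from compound 4 to compound 3, 11-fold (1.04 log units) apart, beyond the scatter of two such steps

The 2-hydroxyphenyl group likewise depends on its setting, giving an 11-fold higher number from compound 2 to compound 4 (1.05 log units; beyond the scatter) when it replaces 3-hydroxyphenyl and a 12-fold higher number from compound 1 to compound 4 (1.07 log units; beyond the scatter) when it replaces 4-hydroxyphenyl, in contrast to its flat step into compound 3: the same change on two cores in this assay, a 1.1-fold higher number (0.03 log units; within the scatter) from compound 2 to compound 3 and a 12-fold higher number (1.07 log units; beyond the scatter) from compound 1 to compound 4, 11-fold (1.04 log units) apart, beyond the scatter of two such steps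

The loss therefore attaches to the combination in compound 4 and not to either group alone, with compound 1, compound 2 and compound 3 showing no such loss.

Going by these compounds, what drives the loss remains open, as does whether it depends on the hydroxyl itself. A methoxy group or an amine in place of the hydroxyl of the 4-hydroxyphenyl group in compound 4 would bear on that.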